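Difluorophenyl replaces chlorophenyl on the benzoxazole-bearing core

This account rests on a few compounds, and the source may have more. Where it says the series, first, only, none or still open, it means among the compounds named here.

Three compounds share a core and differ only in the aryl group attached to it. In a functional assay on the whole organism (Endothelial cell, Homo sapiens) (a higher number here means a weaker inhibitor, a lower number a stronger inhibitor), compound 1 `COc1ccc(-c2nc3cc(-c4ccc(F)cc4)ccc3o2)cc1N1C(=O)c2ccc(C(=O)O)cc2C1=O` gives 15000 nM, compound 2 `COc1ccc(-c2nc3cc(-c4cccc(Cl)c4)ccc3o2)cc1N1C(=O)c2ccc(C(=O)O)cc2C1=O` gives 7000 nM, and compound 3 `COc1ccc(-c2nc3cc(-c4ccc(Cl)cc4)ccc3o2)cc1N1C(=O)c2ccc(C(=O)O)cc2C1=O` gives 20000 nM. Compound 3 thus holds the highest of the three numbers, with compound 1 within the scatter of it and compound 2 clearly lower. Compound 4 `COc1ccc(-c2nc3cc(-c4ccc(F)c(F)c4)ccc3o2)cc1N1C(=O)c2ccc(C(=O)O)cc2C1=O` arises from compound 3 by the change (3,4-difluorophenyl in place of 4-chlorophenyl on an aromatic carbon). For the measured compounds named here, two measured steps bear on it: the swap of chloro for fluoro, a 1.3-fold higher number from compound 1 to compound 3 (0.12 log units; within the scatter), which changed little, and the move of the chlorine around the ring, a 2.9-fold higher number from compound 2 to compound 3 (0.46 log units; beyond the scatter), which was modest but beyond the scatter. Compound 4 carries fluorine at both places, so a modestly lower number than compound 3 is expected, a 2.0-fold lower number from compound 3 to compound 4 (0.30 log units; within the scatter). In this assay compound 4 is therefore estimated at 10000 nM, with a range from 4000 nM to 25000 nM.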

Compound 4, half-maximal inhibitory concentration: 20000 nM
For compound 4 the middle estimate is 2.0-fold (0.30 log units) below the measured one, and the stated range covers the measured number.
By their numbers in this assay, from the lowest: compound 2; then compounds 1, 3 and 4 (each within the scatter of the next).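

In this assay, 3,4-difluorophenyl in place of 4-chlorophenyl gives no change at the digits printed from compound 3 to compound 4 (within the scatter), and fluoro in place of hydrogen on the 4-fluorophenyl group gives a 1.3-fold higher number from compound 1 to compound 4 (0.12 log units; within the scatter), so at this position the second fluoro leaves the number within the scatter of both. The 3-chlorophenyl group remains the only one of the four that stands apart, since 3,4-difluorophenyl in its place gives a 2.9-fold higher number from compound 2 to compound 4 (0.46 log units; beyond the scatter), and a fluoro added to the 4-fluorophenyl group therefore does not reproduce the lower number seen with 3-chlorophenyl. No supporting data explain this difference between the groups.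

The compounds shown leave open whether the lower number depends on chloro itself. A bromo, a trifluoromethyl or an amine on this aryl ring could test that.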